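This account rests on a few compounds, and the source may have more. Where it says the series, first, only, none or still open, it means among the compounds named here.

Compound 1 `CC/C=C/C(=O)Nc1cccc(Oc2nc(Nc3cccc(OC)c3)nc3c2CSCC3)c1`: 24200 nM
Compound 2 `COc1cccc(Nc2nc3c(c(Oc4cccc(NC(=O)C=C(C)C)c4)n2)CSCC3)c1`: > 50000 nM (a limit)

Among the measured compounds shown here, in a functional assay on MCF7 cells (Homo sapiens) for antiproliferative activity, read by MTT assay, with a stated time of 72 h (a higher number here means a weaker inhibitor, a lower number a stronger inhibitor), compound 1 gives 24200 nM, the only actual number in this small set. Compound 2 reads > 50000 nM, which is a limit of the assay, as the limit of > 50000 nM in this assay, at which 1 of the 2 values shown sits, records. Compound 3 `CC/C=C/C(=O)Nc1cccc(Oc2nc(Nc3ccc(OC)cc3)nc3c2CSCC3)c1` departs from compound 1 as follows: 4-methoxyphenyl in place of 3-methoxyphenyl on a nitrogen on an aromatic ring. For the measured compounds named here, the one measured step, an at least 2.0-fold higher number from compound 1 to compound 2 (0.31 log units; beyond the scatter), concerns a different group, so it bears only loosely on this change. No step beyond the scatter is therefore expected in this assay, and the expected step is a 1.0-fold higher number from compound 1 to compound 3 (0.01 log units; within the scatter). The estimated value for compound 3 is 25000 nM, within an expected range of 10000 nM to 50000 nM.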

Compound 3, half-maximal inhibitory concentration: 31400 nM
The estimate for compound 3 lay 1.3-fold (0.10 log units) below the measured number, and the stated range covers the measured number.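

Exchanging 3-methoxyphenyl for 4-methoxyphenyl on the nitrogen gives a 1.3-fold higher number from compound 1 to compound 3 (0.11 log units; within the scatter) in this assay. For this pair, then, moving the methoxy group on this ring changes the number by no more than the scatter, and compound 3 gives a real number as compound 1 does. Compound 2 alone remains a limit of the assay, not a number: the limit of > 50000 nM in this assay, at which 1 of the 3 values shown sits.

Going by these compounds, whether an amine or a carboxylic acid in place of the methoxy group on this ring would move the number beyond the scatter stays open.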